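Oxan-2-yl in place of ethyl: working notes

The source may hold more compounds than are shown below. What is called first, only, known or untested is meant among the compounds shown, and "the series" means these compounds.

Values in a functional assay on KG-1 cells (Homo sapiens) for antiproliferative activity, read by CCK-8 assay, with a stated time of 72 h (on this read-out higher numbers stand for weaker inhibition and lower numbers for stronger inhibition), for the series
- compound 1 `Cc1ccc(C(=O)Nc2cccc(C(F)(F)F)c2)cc1-c1ccc2c(-c3ccc(C(=O)N4CCN(C)CC4)cc3)n[nH]c2c1` gives 300 nM
- compound 2 `CCn1cc(-c2n[nH]c3cc(-c4cc(C(=O)Nc5cccc(C(F)(F)F)c5)ccc4C)ccc23)cn1` gives 257 nM
- compound 3 `Cc1ccc(C(=O)Nc2cccc(C(F)(F)F)c2)cc1-c1ccc2c(-c3cnn(C4CCOC4)c3)n[nH]c2c1` gives 304 nM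

Compound 2 (257 nM) stands within the scatter of both compound 1 and compound 3, so these numbers give no firm order around it. The step under review leads to compound 4 `Cc1ccc(C(=O)Nc2cccc(C(F)(F)F)c2)cc1-c1ccc2c(-c3cnn(C4CCCCO4)c3)n[nH]c2c1` and puts oxan-2-yl in place of ethyl on an aromatic nitrogen. Within the data shown here, one measured step bears directly on this change: oxolan-3-yl in place of ethyl on an aromatic nitrogen gave a 1.2-fold higher number from compound 2 to compound 3 (0.07 log units; within the scatter) and so did not leave the scatter. Compound 1 carries a different group on the shared core, and its value (300 nM) also lies within the scatter of compound 2. Among the measured compounds shown here, no compound with a six-membered non-aromatic ring at this place has been measured, so the support is indirect and a larger step cannot be excluded. On this evidence, no step beyond the scatter is expected in this assay in either direction. The estimated change is a 1.2-fold higher number from compound 2 to compound 4 (0.07 log units; within the scatter) for now. The expected value for compound 4 is 300 nM as an estimate, with an expected range from 140 nM to 700 nM in this series.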

Compound 4, half-maximal inhibitory concentration: 121 nM
Estimate against measurement, compound 4: 2.5-fold (0.39 log units) above, and the stated range ends above it.
By their numbers in this assay, from the lowest: compound 4; then compounds 2, 1 and 3 (each within the scatter of the next).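

This position is no longer flat in this assay: the earlier replacement of ethyl stayed within the scatter (a 1.2-fold higher number from compound 2 to compound 3 (0.07 log units; within the scatter)), whereas oxan-2-yl on the aromatic nitrogen gives a 2.1-fold lower number from compound 2 to compound 4 (0.33 log units; beyond the scatter) and, set against oxolan-3-yl, gives a 2.5-fold lower number from compound 3 to compound 4 (0.40 log units; beyond the scatter). Both steps are modest, but they show that the number responds to the group on this nitrogen, and that a non-aromatic ring with an oxygen is not enough on its own, since compound 3 also carries one and stands within the scatter of compound 2. Among these compounds, nothing measured so far accounts for these steps.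

On these data alone, whether the lower number follows the six-membered ring, the ring oxygen or the point at which the ring is attached stays open, and cyclohexyl, oxan-4-yl and oxolan-2-yl on the same nitrogen would separate these. As far as these compounds go, how far the position tolerates other kinds of group also stays open, for instance a piperidin-4-yl amine or a longer chain ending in a carboxylic acid.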